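A few compounds are considered here, and "the series" means these few. Any claim that something is new, unique, unknown or untested is made for them only; others in the source may bear on it.

Working notes on the series in a functional assay on HT-29 cells (Homo sapiens) for inhibition, read by MTT assay, with a stated time of 48 h; on this read-out lower numbers stand for stronger inhibition and higher numbers for weaker inhibition. Compound 1 `CCSc1nnc(-c2cc(OC)c(OC)c(OC)c2)n1-c1ccc(N(C)C)cc1` reads > 60000 nM, and this is a limit of the assay, not a number (the limit of > 60000 nM in this assay, at which 1 of the 3 values shown sits). Compound 2 `COc1cc(-c2nnc(SCc3ccc(F)cc3)n2-c2ccc(N(C)C)cc2)cc(OC)c1OC` gives 44300 nM, and compound 3 `COc1cc(-c2nnc(SCC(=O)c3ccc(F)cc3)n2-c2ccc(N(C)C)cc2)cc(OC)c1OC` gives 78100 nM. Among the measured compounds shown here, the step between them is a 1.8-fold higher number from compound 2 to compound 3 (0.25 log units; within the scatter), so compound 3 stands level with compound 2, and these two are the only true numbers in the set.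

Compound 4 `COc1cc(-c2nnc(SCC(=O)Nc3ccc(Cl)cc3)n2-c2ccc(N(C)C)cc2)cc(OC)c1OC` changes the group on the carbonyl carbon: (4-chlorophenyl)amino in place of 4-fluorophenyl on a carbonyl carbon. In words, (4-chlorophenyl)amino stands in place of 4-fluorophenyl, turning (4-fluorophenyl)carbonyl into (4-chlorophenyl)carbamoyl. For the measured compounds named here, no measured step makes this exact swap, so the nearest guides are the other changes on the same chain. One is an at least 1.3-fold lower number from compound 1 to compound 2 (0.13 log units; that floor lies within the scatter), whose floor gives no readable gain. Another is a step that the limit leaves unreadable from compound 1 to compound 3, which tells nothing about size. Going by the values given here, the third is a 1.8-fold higher number from compound 2 to compound 3 (0.25 log units; within the scatter), the only step with a full size, and it stays within the scatter. As far as these compounds go, on that basis, no step beyond the scatter is expected, and the direction stays open. The expected step is a 1.6-fold lower number from compound 3 to compound 4 (0.19 log units; within the scatter). For compound 4 the estimated value is 50000 nM, with an expected range from 15000 nM to 110000 nM.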

Compound 4, half-maximal inhibitory concentration: > 60000 nM
Compound 4: only a limit was reported; the forecaster's own chance of this, stated with the estimate: 25%; middle value at least 1.2-fold (0.07 log units) from the limit.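

In this assay compound 4 returns only a limit, not a number, so the (4-chlorophenyl)carbamoyl group adds no third true value to the set, and the limit now takes in more of the series: the limit of > 60000 nM in this assay, at which 2 of the 4 values shown sit.

Among the compounds shown here, the one step that can be read is an at least 1.3-fold higher number from compound 2 to compound 4 (0.13 log units; that floor lies within the scatter); the steps from compound 3 and from compound 1 to compound 4 cannot be read. Even with a carbonyl-bound (4-chlorophenyl)amino group, which brings the amide hydrogen, no group on the saturated chain carbon bound to a sulfur has yet given a readable step beyond the scatter.

The change to compound 4 alters the amino link and the ring halogen at once, so the compounds shown cannot separate the two, and a 4-fluorophenylamino group on the same carbonyl carbon would be needed to do so. As far as these compounds go, whether a carboxylic acid, an amine or a longer chain at this place could give a number clear of the scatter stays open, as does how much of the read-out depends on the shared core rather than on this position.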